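This account rests on a few compounds, and the source may have more. Where it says the series, first, only, none or still open, it means among the compounds named here.

Compound 1 `O=C(/C=C\Nc1ccc(F)cc1)c1nc(-c2ccc(F)cc2)n2ccccc12`: in a functional assay on HCT-116 cells (Homo sapiens) for cytotoxicity, read by MTT assay, with a stated time of 48 h (a lower number here means a stronger inhibitor, a higher number a weaker inhibitor), compound 1 gives > 30000 nM, which is a limit of the assay and not a number.
Compound 2 `O=C(/C=C\Nc1cnc2ccccc2c1)c1nc(-c2ccccc2)n2ccccc12`: in this assay compound 2 gives > 30000 nM, again a limit.
Compound 3 `COc1ccc(N/C=C\C(=O)c2nc(-c3ccc(F)cc3)n3ccccc23)cc1`: in this assay compound 3 gives > 30000 nM, likewise a limit.

Compound 3 therefore stands where every member of the series stands so far, at the limit, with no number behind it (the limit of > 30000 nM in this assay, at which 3 of the 3 values shown sit). Among the measured compounds shown here, the only single-change step among the measured compounds, a step that the two limits leave unreadable from compound 1 to compound 3, is not readable in size, since both ends are limits.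

Compound 4 `COc1ccc(N/C=C\C(=O)c2nc(-c3ccccc3)n3ccccc23)cc1` differs from compound 3 by hydrogen in place of fluoro on an aromatic carbon. For the measured compounds named here, no measured step bears on this particular change; the step from compound 1 to compound 3 touches a different group at the same position and is itself unreadable. With all three values at the limit, no step beyond the scatter can be expected in this assay in either direction, and the outcome is expected to be a further limit. The estimate for compound 4 is 50000 nM (range 20000 nM to 150000 nM), which corresponds to an expected step that the limit leaves unreadable from compound 3 to compound 4.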

Compound 4, half-maximal inhibitory concentration: 7010 nM
Estimate against measurement, compound 4: 7.1-fold (0.85 log units) above; measured number below the stated range.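

Among the compounds shown here, with the 4-fluorophenyl group changed to phenyl, this assay gives the one readable step at this position (an at least 4.2-fold lower number from compound 3 to compound 4 (0.63 log units; beyond the scatter)), so the hydrogen-for-fluoro change separates compound 4 from a limit. Keeping phenyl is not enough alone, since the amine nitrogen substituent also counts (an at least 4.2-fold lower number from compound 2 to compound 4 (0.63 log units; beyond the scatter)). Only compound 4, with phenyl and 4-methoxyphenyl together, leaves the limit shared by the others: the limit of > 30000 nM in this assay, at which 3 of the 4 values shown sit.

The step between compound 1 and compound 3 cannot be read, so fluoro against methoxy on the amine side stays unresolved. From the compounds shown here alone, whether chloro, methyl or an amine in place of that hydrogen on the phenyl ring of compound 4 would keep a readable value remains open.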